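A Thiophene Swap on a Methoxy Nucleoside Core

A few compounds are considered here, and "the series" means these few. Any claim that something is new, unique, unknown or untested is made for them only; others in the source may bear on it.

In a functional assay on A549 cells (Homo sapiens), read by MTT assay, with a stated time of 72 h (on this read-out higher numbers stand for weaker inhibition and lower numbers for stronger inhibition), the measured compounds gave:
compound 1 `O=c1[nH]cnc2c1c(-c1ccoc1)cn2[C@@H]1O[C@H](CO)[C@@H](O)[C@H]1O` — > 20000 nM, a limit of the assay.
compound 2 `COc1ncnc2c1c(-c1ccoc1)cn2[C@@H]1O[C@H](CO)[C@@H](O)[C@H]1O` — 1160 nM.
compound 3 `O=c1[nH]cnc2c1c(-c1cccs1)cn2[C@@H]1O[C@H](CO)[C@@H](O)[C@H]1O` — > 20000 nM, a limit of the assay.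

Among the compounds with values here, compound 2 is the only one with a real number; the other two sit at the limit of > 20000 nM in this assay, at which 2 of the 3 values shown sit. The difference between the cores of compound 1 and compound 2 is not broken down here. From compound 1 to compound 3 the change is thiophen-2-yl in place of furan-3-yl on an aromatic carbon, and the step is a step that the two limits leave unreadable from compound 1 to compound 3. Compound 4 `COc1ncnc2c1c(-c1cccs1)cn2[C@@H]1O[C@H](CO)[C@@H](O)[C@H]1O` carries the same change on the core of compound 2: thiophen-2-yl in place of furan-3-yl on an aromatic carbon. Within the data shown here, the expected step of a 1.7-fold higher number from compound 2 to compound 4 (0.24 log units; within the scatter) in this assay is taken as small, resting only on compound 2 giving 1160 nM as the single number here. Compound 4 is therefore estimated at about 2000 nM, between 600 nM and 8000 nM.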

Compound 4, half-maximal inhibitory concentration: 4850 nM
The estimate for compound 4 lay 2.4-fold (0.38 log units) below the measured number; measured number inside the range.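

Putting thiophen-2-yl in place of furan-3-yl on the core of compound 2 produces a 4.2-fold higher number from compound 2 to compound 4 (0.62 log units; beyond the scatter) in this assay, which means weaker inhibition on that core. The same change on the core of compound 1 cannot be read, because compound 1 and compound 3 both stand at a limit of the assay, not at a number: the limit of > 20000 nM in this assay, at which 2 of the 4 values shown sit. The step is therefore seen on one core only, and the data do not show whether it carries over from one core to the other.

The compounds shown leave open how a phenyl ring or an amine on the same aromatic carbon would compare with furan-3-yl on the core of compound 2. Also open, on these data alone, is what a longer chain, such as ethoxy, would do in place of the methoxy group of compound 2.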